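Removing the Sulfur Substituent: From Compound 3 to Compound 4

This account rests on a few compounds, and the source may have more. Where it says the series, first, only, none or still open, it means among the compounds named here.

Compound 3 `CC(C)c1n[nH]c2c(NCc3ccc(-c4ccccn4)cc3)nc(SC(CO)C(C)C)nc12` carries a 1-(hydroxymethyl)-2-methylpropyl group on its sulfur. In a functional assay on HT cells (Homo sapiens) for antiproliferative activity, read by fluorescence, with a stated time of 72 h (on this read-out lower numbers stand for stronger inhibition of growth and higher numbers for weaker inhibition of growth), compound 3 gives 980 nM, the highest number among the three measured compounds. Compound 1 `CC(C)c1n[nH]c2c(NCc3ccc(-c4ccccn4)cc3)nc(SCC(N)=O)nc12` gives 192 nM and compound 2 `CC(C)c1n[nH]c2c(NCc3ccc(-c4ccccn4)cc3)nc(SC[C@H](O)CN)nc12` gives 63 nM; the steps of a 5.1-fold higher number from compound 1 to compound 3 (0.71 log units; beyond the scatter) and a 16-fold higher number from compound 2 to compound 3 (1.19 log units; beyond the scatter) set compound 3 apart from both. Compound 4 `CC(C)c1n[nH]c2c(NCc3ccc(-c4ccccn4)cc3)nc(S)nc12` differs from compound 3 in one place: hydrogen in place of 1-(hydroxymethyl)-2-methylpropyl on a sulfur. Within the data shown here, no measured step strips the sulfur bare; the two steps ending at compound 3 bear on it only in that they show how far the number moves when the group on the sulfur is exchanged. Because the steps of a 5.1-fold higher number from compound 1 to compound 3 (0.71 log units; beyond the scatter) and a 16-fold higher number from compound 2 to compound 3 (1.19 log units; beyond the scatter) both run upward toward compound 3, the expected step for compound 4 is estimated as a 2.0-fold lower number from compound 3 to compound 4 (0.29 log units; within the scatter), a modest move back downward carrying wide uncertainty. Compound 4 is therefore estimated at 500 nM, with a range from 120 nM to 2500 nM.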

Compound 4, concentration for 50% growth inhibition: 2760 nM
The estimate for compound 4 lay 5.5-fold (0.74 log units) below the measured number, outside the stated range (above it).
By their numbers in this assay, from the lowest: compound 2; then compound 1; then compound 3; then compound 4.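

In this assay, hydrogen on the sulfur gives the highest number of the four compounds, with a 2.8-fold higher number from compound 3 to compound 4 (0.45 log units; beyond the scatter), a 14-fold higher number from compound 1 to compound 4 (1.16 log units; beyond the scatter) and a 44-fold higher number from compound 2 to compound 4 (1.64 log units; beyond the scatter). The earlier steps shown here only exchanged one group on the sulfur for another, whereas these show that all three groups go with a lower number than hydrogen, even the 1-(hydroxymethyl)-2-methylpropyl group of compound 3, which had stood highest until now. Nothing measured here explains this rise.

The compounds shown leave open where a plain ethyl chain on the sulfur, with no hydroxyl, amide or amine, would fall in this order. They also leave open whether a carboxylic acid or a longer amino alcohol chain there would give a number lower than that of compound 2.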